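This account rests on a few compounds, and the source may have more. Where it says the series, first, only, none or still open, it means among the compounds named here.

The measured compounds: compound 1, `CC(C)CSc1nc(N)nc2c1ncn2/C=C1/CC1(CO)CO`; compound 2, `CCCCNc1nc(N)nc2c1ncn2/C=C1/CC1(CO)CO`; compound 3, `Nc1nc2c(ncn2/C=C2/CC2(CO)CO)c(=O)[nH]1`. The unmeasured compound 4 is `CSc1nc(N)nc2c1ncn2/C=C1/CC1(CO)CO`.

In an ADME assay on Akata cells (Homo sapiens) for cytotoxicity, with a stated time of 7 days (on this read-out higher numbers stand for lower toxicity in this test and lower numbers for higher toxicity in this test), compound 1 gives > 20000 nM, a limit of the assay rather than a number. Compound 2 gives > 24000 nM, again only a limit. Compound 3 gives > 20000 nM, also a limit. All three values shown are therefore limits, compound 2 among them; two of them sit at the limit of > 20000 nM in this assay, at which 2 of the 3 values shown sit, and one at the limit of > 24000 nM in this assay, at which 1 of the 3 values shown sits.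

Going by the values given here, the only step measured between two compounds differing in one place is a step that the two limits leave unreadable from compound 1 to compound 2, with butylamino in place of isobutylsulfanyl on an aromatic carbon, and the two limits leave its size unreadable. Compound 4 differs from compound 2 as follows: methylsulfanyl in place of butylamino on an aromatic carbon. Among the compounds with values here, no measured step speaks directly to this change, and the single step available gives no readable size. Within the data shown here, what the data show is only that no compound in the set has reached a measurable value in this assay. The expected step is a step that the limit leaves unreadable from compound 2 to compound 4, nothing beyond the scatter, most likely ending at another limit. For compound 4 the estimate in this assay is 30000 nM, within 15000 nM to 100000 nM.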

Compound 4, half-maximal cytotoxic concentration: > 20000 nM
Compound 4 gave a limit, no number (the forecaster's own chance of this, stated with the estimate: 85%); the middle value does not contradict the limit.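

In this assay compound 4 gives > 20000 nM, which is a limit of the assay and not a number. The steps to compound 4 from compound 1 and from compound 2 therefore cannot be read. The compounds shown leave open whether any change on the shared core would give a measurable value in this assay.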